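The source may report more compounds than this note shows. Statements on the series, on what has been measured and on what is new or still open speak of the compounds shown alone.

Series notes. The shared core of compound 1 `Cn1cc(CN2CCC[C@H](OCc3cc(Cl)cc(Cl)c3)[C@@H]2c2ccccc2)cn1` carries a heteroaryl-methyl group on the ring nitrogen; in an assay on isolated protein for activation of cGMP-dependent protein kinase 1 (Homo sapiens), read by ADP-Glo, with stated times of 120 min and 40 min (a lower number here means that less compound is needed, a higher number that more compound is needed for the effect), compound 1 gives 110000 nM. Compound 2 `O=C(O)c1ccc(CN2CCC[C@H](OCc3cc(Cl)cc(Cl)c3)[C@@H]2c2ccccc2)s1` gives 76000 nM in this assay. For compound 3 `Clc1cc(Cl)cc(CO[C@H]2CCCN(Cc3ncco3)[C@H]2c2ccccc2)c1` this assay reports only a limit, > 200000 nM. Compound 3 is thus the one of the three whose value sits at the limit of > 200000 nM in this assay, at which 1 of the 3 values shown sits; the steps of an at least 1.8-fold higher number from compound 1 to compound 3 (0.25 log units; that floor lies within the scatter) and an at least 2.6-fold higher number from compound 2 to compound 3 (0.42 log units; beyond the scatter) both run towards higher numbers, while a 1.4-fold lower number from compound 1 to compound 2 (0.16 log units; within the scatter) does not separate the two other heteroaryl groups from each other. Compound 4 `CN1CCC[C@H](OCc2cc(Cl)cc(Cl)c2)[C@@H]1c1ccccc1` drops the heteroaryl altogether: hydrogen in place of 1,3-oxazol-2-yl on a saturated chain carbon bound to an amine nitrogen in a ring. Among the measured compounds shown here, no measured step swaps a heteroaryl for hydrogen on this carbon; the three measured steps only compare one heteroaryl with another, and they show that exchanging the ring on this carbon moves the number by no more than a modest amount in this assay. The change to compound 4 is therefore not anchored by any measured pair, and the expectation rests mainly on compound 3 standing at a limit. Compound 4 is expected to remain near that limit, with an estimated step of a number no higher from compound 3 to compound 4 (the limit leaves the size open). The estimate for compound 4 is 200000 nM, with a range from 70000 nM to 600000 nM.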

Compound 4, half-maximal effective concentration: > 200000 nM
Compound 4: no number, only a limit; the forecaster's own chance of this, stated with the estimate: 60%; the middle value sits exactly at the limit.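

With hydrogen in place of the heteroaryl, leaving methyl on the ring nitrogen, the series gains its first comparison at this carbon without a ring in this assay: an at least 2.6-fold higher number from compound 2 to compound 4 (0.42 log units; beyond the scatter), and this step lies beyond the scatter, whereas an at least 1.8-fold higher number from compound 1 to compound 4 (0.25 log units; that floor lies within the scatter), and that floor lies within it. The step between compound 3 and compound 4 cannot be read, since both values are limits, so hydrogen and 1,3-oxazol-2-yl cannot be told apart here. Of the groups compared at this carbon, only 1-methyl-1H-pyrazol-4-yl and 5-carboxythiophen-2-yl give a number rather than a limit, and the ceiling now holds the compound without a heteroaryl as well as compound 3: the limit of > 200000 nM in this assay, at which 2 of the 4 values shown sit.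

Going by these compounds, how far compound 3 and compound 4 lie beyond their limits stays open, and with it whether 1,3-oxazol-2-yl differs from hydrogen at all in this assay. Also open, on these data alone, is whether another group on this carbon, such as a longer chain ending in an amine, would bring the number well below those of compound 1 and compound 2, which themselves lie within the scatter of each other.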